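A few compounds are considered here, and "the series" means these few. Any claim that something is new, unique, unknown or untested is made for them only; others in the source may bear on it.

The study measures compounds in a functional assay on the whole organism (strain albino) for inhibition, with Rattus norvegicus as the target, read by paw edema, with a stated time of 3 h, at a dose of 0.28 mmol/kg by the oral route; a higher number here means more inhibition at the dose given (going by the name of the read-out), a lower number less inhibition. Compound 1 `COc1ccc(-c2nnc(SC/C(=N/O)c3ccccc3)n2-c2ccccc2)cc1` gives 63%; compound 2 `O/N=C(/CSc1nnc(-c2ccccc2)n1-c1ccccc1)c1ccccc1` gives 65%; compound 3 `CCn1c(SC/C(=N/O)c2ccccc2)nnc1-c1ccc(OC)cc1` gives 75%. Compound 3 holds the highest of the three numbers, though compound 2 lies within the scatter of it, while compound 1 lies beyond it, the change being a number 12 percentage points higher from compound 1 to compound 3 (beyond the scatter).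

Compound 4 `CCn1c(SC/C(=N/O)c2ccccc2)nnc1-c1ccccc1` differs from compound 3 by hydrogen in place of methoxy on an aromatic carbon. The same change was seen between two measured compounds, where it gave a number 2 percentage points higher from compound 1 to compound 2 (within the scatter), a shift within the scatter. For the measured compounds named here, the one bearing step therefore suggests no change beyond the scatter in this assay, and the step from compound 3 to compound 4 is expected to be a number 1 percentage points higher from compound 3 to compound 4 (within the scatter). Compound 4 is accordingly estimated at 76%, with a range from 64% to 88%.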

Compound 4, a percentage reported as inhibition, in the whole organism at one dose (the size of the read-out at that dose, not a potency): 72%
Estimate against measurement, compound 4: 4 percentage points above; measured number inside the range.
By their numbers in this assay, from the lowest: compounds 1, 2, 4 and 3 (each within the scatter of the next, the first and the last beyond it).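

In this assay, the change from 4-methoxyphenyl to phenyl now gives a number 3 percentage points lower from compound 3 to compound 4 (within the scatter), so on a second core, carrying ethyl rather than phenyl on the aromatic nitrogen, this position again shows no shift beyond the scatter: the same change on two cores in this assay, a number 2 percentage points higher (within the scatter) from compound 1 to compound 2 and a number 3 percentage points lower (within the scatter) from compound 3 to compound 4, 5 percentage points apart, within the scatter of two such steps. Ethyl in place of phenyl, beyond the scatter with methoxy present, gives a number 7 percentage points higher from compound 2 to compound 4 (within the scatter) without it, yet the two steps do not differ beyond the scatter: the same change on two cores in this assay, a number 12 percentage points higher (beyond the scatter) from compound 1 to compound 3 and a number 7 percentage points higher (within the scatter) from compound 2 to compound 4, 5 percentage points apart, within the scatter of two such steps.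

On these data alone, it remains open whether a chlorine atom or a hydroxyl at this place would move the inhibition beyond the scatter. As far as these compounds go, whether a longer chain than ethyl on the nitrogen would do so also remains open.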